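The compounds below may be only part of what the source reports. "The series", "measured", "known", "first", "only" and "open" are said of these compounds alone.

Measured compounds:
compound 1 `COc1ccccc1N1CCN(CC(=O)N2CCN(c3nnc(-c4ccc(C)cc4)c(-c4ccc(C)cc4)n3)CC2)CC1`, 133000 nM
compound 2 `Cc1ccc(-c2nnc(N3CCN(C(=O)CN4CCN(c5ccccc5Cl)CC4)CC3)nc2-c2ccc(C)cc2)cc1`, > 859000 nM
compound 3 `COc1ccc(-c2nnc(N3CCN(C(=O)CN4CCN(c5ccccc5OC)CC4)CC3)nc2-c2ccc(OC)cc2)cc1`, > 821000 nM

In an ADME assay on NIH3T3 cells (Mus musculus) for cytotoxicity, read by MTT assay, with a stated time of 24 h (on this read-out lower numbers stand for stronger inhibition and higher numbers for weaker inhibition), compound 1 gives 133000 nM. For compound 2 the read-out is a limit only, > 859000 nM. For compound 3 the read-out is likewise a limit only, > 821000 nM. The change from compound 1 to compound 2 is chloro in place of methoxy on an aromatic carbon, and it gives an at least 6.4-fold higher number from compound 1 to compound 2 (0.81 log units; beyond the scatter). How the core of compound 1 differs from the core of compound 3 is not broken down here.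

Compound 4 `COc1ccc(-c2nnc(N3CCN(C(=O)CN4CCN(c5ccccc5Cl)CC4)CC3)nc2-c2ccc(OC)cc2)cc1` is not yet measured. It differs from compound 3 by chloro in place of methoxy on an aromatic carbon, the same change as between compound 1 and compound 2, at a place described in the same words. Because of an at least 6.4-fold higher number from compound 1 to compound 2 (0.81 log units; beyond the scatter) the expected step in this assay is a step that the limit leaves unreadable from compound 3 to compound 4, a number no smaller than that of compound 3. Compound 4 is therefore expected to give 1500000 nM in this assay, within 821000 nM to 5000000 nM, and most likely reported only as a limit.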

Compound 4, half-maximal inhibitory concentration: > 814000 nM
Compound 4 was reported as a limit (the forecaster's own chance of this, stated with the estimate: 85%); the middle value lies beyond the limit too.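

In this assay compound 4 gives only a limit (> 814000 nM). Among the compounds shown here, compound 3 also stands only as a limit, so no step between compound 3 and compound 4 can be read. Still open, as far as these compounds go, is whether 2-methoxyphenyl to 2-chlorophenyl changes the number on the core of compound 3 as it does on the core of compound 1.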